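Smaller Amine on the Thiocarbonyl: Pyrrolidine Replaces Pyridylmethyl

The compounds below may be only part of what the source reports. "The series", "measured", "known", "first", "only" and "open" are said of these compounds alone.

Going by the values given here, compound 2 `CCN(Cc1ccncc1)C(=S)SCc1ccc(C(=O)Nc2ccccc2N)cc1` holds the higher of the two numbers known in a functional assay on HeLa cells (Homo sapiens) for antiproliferative activity, read by CCK-8 assay, with a stated time of 72 h, tested at 2 uM (a higher number here means a stronger effect of the compound at the concentration tested, a lower number a weaker effect), where compound 2 gives 63.5%. Its nearest neighbour is compound 1 `Nc1ccccc1NC(=O)c1ccc(CSC(=S)N2CCc3cc(Cl)ccc32)cc1`, which in this assay gives 40.1%. Among the compounds with values here, the one measured step runs between them: a number 23.4 percentage points higher from compound 1 to compound 2 (beyond the scatter), for ethyl((pyridin-4-yl)methyl)amino in place of 5-chloro-2,3-dihydro-1H-indol-1-yl on a thiocarbonyl carbon.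

Compound 3 `Nc1ccccc1NC(=O)c1ccc(CSC(=S)N2CCCC2)cc1` has not yet been measured in this assay. It differs from compound 2 in one place: pyrrolidin-1-yl in place of ethyl((pyridin-4-yl)methyl)amino on a thiocarbonyl carbon.

Within the data shown here, only the step from compound 1 to compound 2 bears on this change, and only loosely, since it exchanges one amine on the thiocarbonyl carbon for another rather than introducing pyrrolidin-1-yl itself. That step was modest. Among the measured compounds shown here, with the pyridine ring gone and a small saturated ring in its place, the number is expected to fall back part of the way toward compound 1, by a number 13.5 percentage points lower from compound 2 to compound 3 (beyond the scatter), though the scatter of this assay leaves room for no step at all. Compound 3 is therefore estimated to give 50% in this assay, within a range of 30% to 70%.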

Compound 3, a percentage reported as inhibition, at one concentration (the size of the read-out at that concentration, not a potency): 51.3%
The estimate for compound 3 lay 1.3 percentage points below the measured number, and the stated range covers the measured number.
By their numbers in this assay, from the lowest: compound 1; then compound 3; then compound 2.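

In this assay, pyrrolidin-1-yl on the thiocarbonyl carbon sets compound 3 at a middle level, with a number 12.2 percentage points lower from compound 2 to compound 3 (beyond the scatter) and a number 11.2 percentage points higher from compound 1 to compound 3 (beyond the scatter). The three amines at this one place therefore give three separate levels, each step lying beyond the scatter, so the read-out responds to the choice of amine and the pyridine ring of compound 2 is not needed for a number above that of compound 1, though compound 2 still holds the highest number of the three. No measurement at hand accounts for this order, so the data describe the ranking without explaining it.

From the compounds shown here alone, what remains open is which part of the ethyl((pyridin-4-yl)methyl)amino group carries the higher number of compound 2: a benzyl(ethyl)amino group, with a plain benzene ring in place of the pyridine, would test the ring nitrogen, and diethylamino would test the need for any aromatic ring at all. The compounds shown also do not tell whether the ring size of the saturated amine matters, as piperidine, azetidine or morpholine on the same thiocarbonyl carbon could show.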